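Aryloxymethyl series: meta chloro as the next variation

The source may hold more compounds than are shown below. What is called first, only, known or untested is meant among the compounds shown, and "the series" means these compounds.

Measured compounds in a functional assay on CHO cells for agonist activity at prostaglandin E2 receptor EP2 subtype (Homo sapiens), read by HTRF and cAMP accumulation, with a stated time of 30 min; on this read-out higher numbers stand for an effect only at larger amounts of compound and lower numbers for an effect already at smaller amounts:
- compound 1 `O=C(O)c1csc([C@H]2CC[C@@H]3[C@@H](COc4ccccc4F)[C@H](O)C[C@@H]3O2)n1` gives 23 nM
- compound 2 `Cc1ccc(OC[C@@H]2[C@H]3CC[C@H](c4nc(C(=O)O)cs4)O[C@H]3C[C@H]2O)cc1` gives 27 nM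
- compound 3 `O=C(O)c1csc([C@H]2CC[C@@H]3[C@@H](COc4cccc(F)c4)[C@H](O)C[C@@H]3O2)n1` gives 5.4 nM

Compound 3 stands lowest of the three numbers, separated from compound 1 and compound 2 beyond the scatter, as shown by a 4.3-fold lower number from compound 1 to compound 3 (0.63 log units; beyond the scatter) and a 5.0-fold lower number from compound 2 to compound 3 (0.70 log units; beyond the scatter); the gap a 1.2-fold higher number from compound 1 to compound 2 (0.07 log units; within the scatter) lies within the scatter.

Compound 4 `O=C(O)c1csc([C@H]2CC[C@@H]3[C@@H](COc4cccc(Cl)c4)[C@H](O)C[C@@H]3O2)n1` differs from compound 3 only by chloro in place of fluoro on an aromatic carbon. Among the compounds with values here, none of the measured steps exchanges one halogen for another; the three steps vary the ring substituent's position and identity together, so they bear on this change only indirectly. A step of modest size at most is expected in this assay, direction open, likely within the scatter, as a 1.1-fold lower number from compound 3 to compound 4 (0.03 log units; within the scatter).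

Compound 4 is therefore estimated at 5 nM, with a range from 1.5 nM to 18 nM.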

Compound 4, half-maximal effective concentration: 6.5 nM
The estimate for compound 4 lay 1.3-fold (0.11 log units) below the measured number; measured number inside the range.
By their numbers in this assay, from the lowest: compounds 3 and 4 (each within the scatter of the next); then compounds 1 and 2 (each within the scatter of the next).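

In this assay, chloro and fluoro on this aromatic carbon, meta to a large group, cannot be told apart (a 1.2-fold higher number from compound 3 to compound 4 (0.08 log units; within the scatter)). The separation from the other aryl groups also holds with 3-chlorophenyl (a 4.2-fold lower number from compound 2 to compound 4 (0.62 log units; beyond the scatter); a 3.5-fold lower number from compound 1 to compound 4 (0.55 log units; beyond the scatter)), so among these compounds it is not confined to 3-fluorophenyl. No available measurement bears on the basis of these numbers.

Open, as far as these compounds go, is whether a methoxy, trifluoromethyl or nitrile group at this position gives numbers like those of the two halogens. Also open, from the compounds shown here alone, is how chloro behaves on other ring carbons.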